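The compounds below may be only part of what the source reports. "The series", "measured", "known", "first", "only" and "open" are said of these compounds alone.

Measured so far in an ADME assay for permeability, using PAMPA, at pH 7.4; a higher number here means that the compound crosses the layer faster, a lower number that the compound crosses the layer more slowly:
- compound 1 `O=C(Nc1ccc(F)c(-c2nc3ccccc3o2)c1)c1cc([N+](=O)[O-])ccc1Cl`: 366 10^-6 cm/s
- compound 2 `COc1ccc(-c2nc3ccccc3o2)cc1NC(=O)c1cc([N+](=O)[O-])ccc1Cl`: 274 10^-6 cm/s
- compound 3 `O=C(Nc1ccc(F)c(-c2nc3ccccc3s2)c1)c1cc([N+](=O)[O-])ccc1Cl`: 17 10^-6 cm/s

Compound 3 is the lowest of the three, and the other two compounds both lie beyond the scatter above it. Going by the values given here, the only measured step between compounds differing in one place is large: a 22-fold lower number from compound 1 to compound 3 (1.33 log units; beyond the scatter), with 1,3-benzothiazol-2-yl in place of 1,3-benzoxazol-2-yl on an aromatic carbon. That group is unchanged in compound 4 `COc1ccc(NC(=O)c2cc([N+](=O)[O-])ccc2Cl)cc1-c1nc2ccccc2s1`, so the step does not test the new change, which is methoxy in place of fluoro on an aromatic carbon. Among the compounds with values here, no measured step shows this swap directly. Compound 2 also carries methoxy, but it differs from compound 1 in more than one place. Compound 1 at 366 10^-6 cm/s and compound 2 at 274 10^-6 cm/s lie within the scatter of each other, so nothing points to a large shift. The expected change is therefore small and within the scatter, estimated as a 1.2-fold higher number from compound 3 to compound 4 (0.07 log units; within the scatter) here. For compound 4 the estimated value is 20 10^-6 cm/s, with an expected range from 6 10^-6 cm/s to 70 10^-6 cm/s as its ends.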

Compound 4, apparent permeability in the ADME assay: "below limit of detection" (no number reported)
The entry for compound 4 holds no number, so the estimate cannot be set against anything.
By their numbers in the ADME assay, from the lowest: compound 3; then compounds 2 and 1 (each within the scatter of the next).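

Going by these compounds alone, in the ADME assay compound 4 gives "below limit of detection" (no number reported), which holds no number, so no step from compound 3 to compound 4 can be read. From the compounds shown here alone, how far methoxy in place of fluoro shifts this read-out stays open. In a physicochemical assay for solubility, read by spectrophotometry, in phosphate buffer, measured as kinetic solubility, with a stated time of 18 h, at pH 7.4 (a lower number here means a less soluble compound, a higher number a more soluble compound), compound 3 gives 490 nM and compound 4 gives 260 nM, and these two values lie within the scatter of each other. No evidence at hand bears on this result.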